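Removing the ethoxy group from compound 3

A few compounds are considered here, and "the series" means these few. Any claim that something is new, unique, unknown or untested is made for them only; others in the source may bear on it.

Of the compounds shown here, three sharing one core have been measured in a functional assay on A549 cells (Homo sapiens) for antiproliferative activity, read by MTT assay, with a stated time of 48 h; on this read-out lower numbers stand for stronger inhibition and higher numbers for weaker inhibition. Compound 1 (`COc1ccc(/C=C/c2cc(OC)cc(OC)c2/C=C/C(=O)c2ccc(C(F)(F)F)cc2)cc1`), which carries trifluoromethyl, gives 7.8 ug/mL. Compound 2 (`COc1ccc(/C=C/c2cc(OC)cc(OC)c2/C=C/C(=O)c2ccc(N)cc2)cc1`), which carries amino at the same place, gives 3.8 ug/mL. Compound 3 (`CCOc1ccc(C(=O)/C=C/c2c(/C=C/c3ccc(OC)cc3)cc(OC)cc2OC)cc1`), which carries ethoxy there, gives 7.5 ug/mL. That value lies within the scatter of both neighbours, as a 1.0-fold lower number from compound 1 to compound 3 (0.02 log units; within the scatter) and a 2.0-fold higher number from compound 2 to compound 3 (0.30 log units; within the scatter) show.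

Compound 4 (`COc1ccc(/C=C/c2cc(OC)cc(OC)c2/C=C/C(=O)c2ccccc2)cc1`) has hydrogen in place of ethoxy on an aromatic carbon, para to a large group: hydrogen in place of ethoxy on an aromatic carbon. Among the measured compounds shown here, no measured compound yet has hydrogen at this place, so the evidence is indirect. The three measured steps all exchange one group for another at this place. The only one beyond the scatter is a 2.1-fold lower number from compound 1 to compound 2 (0.31 log units; beyond the scatter), and that step is modest. Two of the three groups tried give values within the scatter of each other, so no clear direction emerges, and a change beyond the scatter is not expected. The expected result is a 1.2-fold lower number from compound 3 to compound 4 (0.06 log units; within the scatter). In this assay, compound 4 is estimated at 6.5 ug/mL, with an expected range from 3.2 ug/mL to 13 ug/mL.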

Compound 4, half-maximal inhibitory concentration: 3.9 ug/mL
Compound 4: middle estimate off by 1.7-fold (0.22 log units), on the high side; the measured number falls inside the stated range.
By their numbers in this assay, from the lowest: compounds 2, 4, 3 and 1 (each within the scatter of the next, the first and the last beyond it).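

Among the compounds shown here, with hydrogen now at this place, on an aromatic carbon para to a large group, the three substituted compounds can for the first time be set against the compound without a substituent in this assay. All three comparisons lie within the scatter: ethoxy (a 1.9-fold lower number from compound 3 to compound 4 (0.28 log units; within the scatter)), amino (a 1.0-fold higher number from compound 2 to compound 4 (0.01 log units; within the scatter)) and trifluoromethyl (a 2.0-fold lower number from compound 1 to compound 4 (0.30 log units; within the scatter)). None of these groups is thus separated from hydrogen beyond the scatter, and the one step beyond it in this set, the exchange of trifluoromethyl for amino (a 2.1-fold lower number from compound 1 to compound 2 (0.31 log units; beyond the scatter)), stands as a gap between two groups that compound 4 does not resolve into a gain or a loss relative to hydrogen; no measurement shown offers an explanation for these values.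

What the compounds shown leave open is whether any group at this place can move the number beyond the scatter of compound 4, for instance a carboxylic acid, a hydroxy group or a longer alkoxy chain such as butoxy. They also leave open whether the small gap between amino and trifluoromethyl would hold up on repeated measurement or in cell lines other than the one used in this assay.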